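A few compounds are considered here, and "the series" means these few. Any claim that something is new, unique, unknown or untested is made for them only; others in the source may bear on it.

Working notes on the series. Compound 1 `Cc1ccc2cc([C@H](C)Nc3ncnc(N)c3C#N)c(-c3ccccc3)c(=O)n2c1` has an entry of "not determined" (no result reported) in an ADME assay on microsomes from liver (Homo sapiens), read by LC-MS, using NADPH, with a stated time of 30 min, tested at 1 uM (on this read-out lower numbers stand for a less stable compound and higher numbers for a more stable compound), and compound 3 `C[C@H](Nc1nc(N)nc(N)c1C#N)c1cc(=O)n2cc(F)ccc2c1-c1ccccc1` likewise stands at "not determined" (no result reported) there, so compound 3 carries no number on this read-out. Within the data shown here, the one number in the set comes from compound 2 `C[C@H](Nc1nc(N)nc(N)c1C#N)c1cc2ccc(F)cn2c(=O)c1-c1ccc(F)cc1`, which gives 87% in this assay. Compound 4 `C[C@H](Nc1ncnc(N)c1C#N)c1cc(=O)n2cc(F)ccc2c1-c1ccccc1` differs from compound 3 by the change (hydrogen in place of amino on an aromatic carbon), hydrogen in place of amino on an aromatic carbon. Among the measured compounds shown here, no measured pair shows this change, so the size of the step is open; given the one value in hand, the expectation is a step of modest size, toward less remaining, possibly within the scatter. Compound 4 is estimated at 75%, with a range of 40% to 95%.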

Compound 4, percent of the compound remaining: 90%
Compound 4: middle estimate off by 15 percentage points, on the low side, within the range that was stated.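

Among these compounds, compound 3 carries no number in this assay, so no step to compound 4 at 90% can be read. On these data alone, the size of the change from amino to hydrogen stays open, and no supporting data bear on this result.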